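Side-chain exchange on the shared core: compound 2 to compound 3

The compounds below may be only part of what the source reports. "The series", "measured", "known", "first", "only" and "open" are said of these compounds alone.

Measured in a functional assay on CCRF-CEM cells (Homo sapiens); on this read-out higher numbers stand for lower toxicity in this test and lower numbers for higher toxicity in this test:
- compound 1 `CNC(=O)Cn1c(=O)c(C)cn([C@@H]2O[C@H](CO[Si](C)(C)C(C)(C)C)[C@@]3(OS(=O)(=O)C=C3N)[C@H]2O[Si](C)(C)C(C)(C)C)c1=O`: >= 250000 nM (a limit of the assay, not a number)
- compound 2 `Cc1cn([C@@H]2O[C@H](CO[Si](C)(C)C(C)(C)C)[C@@]3(OS(=O)(=O)C=C3N)[C@H]2O[Si](C)(C)C(C)(C)C)c(=O)n(CC(=O)N(C)C)c1=O`: 245000 nM

Within the data shown here, compound 2 holds the only actual number so far. Among the measured compounds shown here, the single measured step, an at least 1.0-fold lower number from compound 1 to compound 2 (0.00 log units; that floor lies within the scatter), is methyl in place of hydrogen on an amide-type nitrogen, and it stays within the scatter.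

Compound 3 `COC(=O)/C=C/Cn1c(=O)c(C)cn([C@@H]2O[C@H](CO[Si](C)(C)C(C)(C)C)[C@@]3(OS(=O)(=O)C=C3N)[C@H]2O[Si](C)(C)C(C)(C)C)c1=O` carries 2-(methoxycarbonyl)ethenyl in place of dimethylcarbamoyl on a saturated chain carbon bound to an aromatic nitrogen. For the measured compounds named here, no measured step covers this exchange, so that one small step is the only guide, and it is a weak one. A higher reading for compound 3 would soon meet the limit reached by compound 1, (the limit of >= 250000 nM in this assay, at which 1 of the 2 values shown sits). A lower number is therefore the likelier direction, though no change beyond the scatter is expected in this assay. The expected step is a 1.8-fold lower number from compound 2 to compound 3 (0.24 log units; within the scatter). For compound 3 the estimated value is 140000 nM, with an expected range of 40000 nM to 250000 nM.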

Compound 3, half-maximal cytotoxic concentration: 142000 nM
For compound 3 the middle estimate is 1.0-fold (0.01 log units) below the measured one; the measured number falls inside the stated range.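

In this assay, replacing the whole amide end of the side chain with an unsaturated ester gives a 1.7-fold lower number from compound 2 to compound 3 (0.24 log units; within the scatter), whereas the earlier step changed only a methyl on the amide nitrogen. At this place on the shared core, a side chain with no amide nitrogen therefore gives a reading that cannot be told apart from that of the dimethylcarbamoyl side chain, and compound 3 supplies a second actual number for the series. Set against the methylcarbamoyl side chain, the exchange gives an at least 1.7-fold lower number from compound 1 to compound 3 (0.24 log units; that floor lies within the scatter), and this too shows no change beyond the scatter, while the value of compound 1 is a limit of the assay and not a number: the limit of >= 250000 nM in this assay, at which 1 of the 3 values shown sits.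

The compounds shown leave open whether any side chain at this place can move the reading beyond the scatter, since every step so far lies within it. A carboxylic acid in place of the methyl ester, a saturated chain in place of the ethenyl link, or an amine at the end of the chain would test that directly.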